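Moving the acyl substituent from 2-methylphenyl to 3-methoxyphenyl

The source may hold more compounds than are shown below. What is called first, only, known or untested is meant among the compounds shown, and "the series" means these compounds.

Three compounds share a core and differ only in the aryl group on the carbonyl carbon of the amide. Compound 1 `Cc1ccc(C(=O)Nc2cccc(-c3oc4cc(-c5ccc(F)cc5)ccc4c(=O)c3O)c2)cc1` carries a 4-methylphenyl group and gives 2320 nM in a functional assay on HepG2 cells (Homo sapiens) for antiproliferative activity, read by CCK-8 assay, with a stated time of 72 h; a higher number here means a weaker inhibitor, a lower number a stronger inhibitor. Compound 2 `O=C(Nc1cccc(-c2oc3cc(-c4ccc(F)cc4)ccc3c(=O)c2O)c1)c1ccc(F)cc1F` carries a 2,4-difluorophenyl group and gives 26400 nM in this assay. Compound 3 `Cc1ccccc1C(=O)Nc1cccc(-c2oc3cc(-c4ccc(F)cc4)ccc3c(=O)c2O)c1` carries a 2-methylphenyl group and gives 19400 nM in this assay, the second highest of the three numbers; it stands a 1.4-fold lower number from compound 2 to compound 3 (0.13 log units; within the scatter), and an 8.4-fold higher number from compound 1 to compound 3 (0.92 log units; beyond the scatter).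

Compound 4 `COc1cccc(C(=O)Nc2cccc(-c3oc4cc(-c5ccc(F)cc5)ccc4c(=O)c3O)c2)c1` is not yet measured. It differs from compound 3 in that (3-methoxyphenyl in place of 2-methylphenyl on a carbonyl carbon). For the measured compounds named here, no measured step pairs a methoxy-bearing aryl group with any other, so the only guidance is that the 4-methylphenyl of compound 1 gave a lower number than the 2-methylphenyl of compound 3, while the 2,4-difluorophenyl of compound 2 sat within the scatter of compound 3. Compound 4 is expected to lie between these poles, giving an estimated 9000 nM (range 2500 nM to 30000 nM), which amounts to an expected 2.2-fold lower number from compound 3 to compound 4 (0.33 log units; beyond the scatter).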

Compound 4, half-maximal inhibitory concentration: 9950 nM
Compound 4: the middle estimate sits 1.1-fold (0.04 log units) below what was measured; low and high end bracket the measured number.
By their numbers in this assay, from the lowest: compound 1; then compounds 4, 3 and 2 (each within the scatter of the next, the first and the last beyond it).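

In this assay, for the compounds shown here, the first methoxy-bearing aryl group on this carbonyl carbon cannot be told apart from the 2-methylphenyl group (a 1.9-fold lower number from compound 3 to compound 4 (0.29 log units; within the scatter)), even though it adds an oxygen and a hydrogen-bond acceptor that the departing group lacks. It does separate from the other two groups (a 2.7-fold lower number from compound 2 to compound 4 (0.42 log units; beyond the scatter); a 4.3-fold higher number from compound 1 to compound 4 (0.63 log units; beyond the scatter)), so compound 4 stands clear of compound 2, which compound 3 does not, and the 4-methylphenyl group of compound 1 keeps the lowest number of the four. No evidence at hand accounts for these differences.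

The compounds shown leave open whether a 4-methoxyphenyl group would match the 4-methylphenyl group of compound 1. They also leave open whether an aryl group carrying an amine or a carboxylic acid would fall outside this range.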